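The compounds below may be only part of what the source reports. "The series", "measured", "known", "first", "only" and "open" are said of these compounds alone.

Compound 1 `O=C(Nc1ccccc1)c1cccc(Br)c1O` gives in an assay for inhibition of HSP60/HSP10 (Homo sapiens), with a stated time of 60 min (a lower number here means a stronger inhibitor, a higher number a weaker inhibitor), the reading > 100000 nM, which is a limit of the assay and not a number.
Compound 2 `COc1c(Br)cccc1C(=O)Nc1ccccc1` gives in this assay the reading > 100000 nM, again a limit.
Compound 3 `COc1c(Br)cccc1C(=O)Nc1cccc(Cl)c1` gives in this assay the reading > 100000 nM, once more a limit.

All three measured compounds sit at the limit of > 100000 nM in this assay, at which 3 of the 3 values shown sit, so compound 2 stands at the limit, with nothing around it that is a true number. The two measured steps both touch compound 2: the change from compound 1 to compound 2 in this assay is a step that the two limits leave unreadable from compound 1 to compound 2, and the change from compound 2 to compound 3 is a step that the two limits leave unreadable from compound 2 to compound 3. Neither can be read, because each the limit of > 100000 nM in this assay, at which 3 of the 3 values shown sit, hides how far beyond it the compounds really lie.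

Compound 4 `COc1ccccc1C(=O)Nc1ccccc1` has not yet been measured. It differs from compound 2 as follows: hydrogen in place of bromo on an aromatic carbon. For the measured compounds named here, no measured step removes a bromo group, so nothing here bears directly on this change; the only guide is that every compound that shares this core sits at the limit. The step from compound 2 to compound 4 is therefore expected to be a step that the limit leaves unreadable from compound 2 to compound 4, in effect no readable change. Compound 4 is expected to give about 150000 nM, within a range of 30000 nM to 1000000 nM, most probably reported as a limit again.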

Compound 4, half-maximal inhibitory concentration: > 100000 nM
Compound 4 gave a limit, no number (the forecaster's own chance of this, stated with the estimate: 85%); the middle value does not contradict the limit.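

Compound 2 and compound 4 both end at the assay limit rather than at a true number, so the step between them, hydrogen in place of bromo, cannot be read: the limit of > 100000 nM in this assay, at which 4 of the 4 values shown sit.

The compounds shown leave open whether any change to the shared core would give a true number in this assay, and which groups would matter for it.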